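From 2-Hydroxyethoxy to (2-Hydroxyethyl)sulfanyl on a Shared Core

This account rests on a few compounds, and the source may have more. Where it says the series, first, only, none or still open, it means among the compounds named here.

Measured so far:
Compound 1, `OCCOCc1c(-c2ccccc2)nc2ccccn12`: 400 ug/mL
Compound 2, `Cc1ccn2c(CSCCO)cnc2c1`: 100 ug/mL

Both compounds were tested in a functional assay on Vero cells (Chlorocebus sabaeus) for cytotoxicity; on this read-out lower numbers stand for higher toxicity in this test and higher numbers for lower toxicity in this test. Compound 1 gives 400 ug/mL, which is the higher of the two numbers, so it is the less toxic compound in this test. Compound 2 gives 100 ug/mL, a lower number that lies beyond the usual scatter, so compound 2 is the more toxic of the two here. The two compounds differ in several places at once, so no single structural cause can be read from this pair.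

Compound 3, `OCCSCc1c(-c2ccccc2)nc2ccccn12`, has not yet been measured in this assay. Compared with compound 1, the change is (2-hydroxyethyl)sulfanyl in place of 2-hydroxyethoxy on a saturated chain carbon bound to an aromatic carbon. The rest of the molecule is kept as it stands in compound 1. Among the measured compounds shown here, no measured pair shows this exchange on its own, so there is no direct precedent to lean on.

A step of modest size, if any, is expected, with the number for compound 3 a little lower than for compound 1 and a 1.3-fold lower number from compound 1 to compound 3 (0.12 log units; within the scatter) likely within or close to the scatter. Compound 3 is estimated at 300 ug/mL, in the range 100 ug/mL to 800 ug/mL.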

Compound 3, minimum cytotoxic concentration: 40 ug/mL
Beside the measured number, compound 3's estimate is 7.5-fold (0.88 log units) above it; the whole stated range lies above it.
By their numbers in this assay, from the lowest: compound 3; then compound 2; then compound 1.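

In this assay, putting (2-hydroxyethyl)sulfanyl in place of 2-hydroxyethoxy on a saturated chain carbon bound to an aromatic carbon gives a 10-fold lower number from compound 1 to compound 3 (1.00 log units; beyond the scatter) and so shows that this single exchange, with the rest of the molecule kept, makes the compound clearly more toxic in this test. The earlier pair could not show this, as its two compounds differ in several places at once. The two groups have the same counts of heavy atoms, hydrogen-bond donors and hydrogen-bond acceptors, so those counts alone do not settle the number at this position, and nothing measured here explains the size of the step.

Still open is whether the same exchange would give a step of similar size on another core, as compound 2 carries (2-hydroxyethyl)sulfanyl on a different core and no partner with 2-hydroxyethoxy is shown for it. Also open, going by these compounds, is how a simple amine, a carboxylic acid or a longer chain such as (3-hydroxypropyl)sulfanyl would read at this same place on the shared core.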